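From 4-chlorophenyl to 3-chloro-4-fluorophenyl on a sulfonamide

The source may hold more compounds than are shown below. What is called first, only, known or untested is meant among the compounds shown, and "the series" means these compounds.

Measured so far in a functional assay on HeLa cells (Homo sapiens) for inhibition, read by CCK-8 assay, with a stated time of 72 h; a higher number here means a weaker inhibitor, a lower number a stronger inhibitor
Compound 1 `Cc1cccc(NS(=O)(=O)c2cccc(CCCCCCNC(=O)/C=C/c3cccnc3)c2)c1` at 65.8 nM
Compound 2 `O=C(/C=C/c1cccnc1)NCCCCCCc1cccc(S(=O)(=O)Nc2ccc(Cl)cc2)c1` at 170 nM

Compound 2 has the higher number of the two. For the measured compounds named here, the only measured step is a 2.6-fold higher number from compound 1 to compound 2 (0.41 log units; beyond the scatter) and it is modest, with 4-chlorophenyl in place of 3-methylphenyl on a sulfonamide nitrogen. Compound 3 `O=C(/C=C/c1cccnc1)NCCCCCCc1cccc(S(=O)(=O)Nc2ccc(F)c(Cl)c2)c1` carries 3-chloro-4-fluorophenyl in place of 4-chlorophenyl at that same place, and the change reads 3-chloro-4-fluorophenyl in place of 4-chlorophenyl on a sulfonamide nitrogen in full. Going by the values given here, that one step is the only guide, so a shift no larger than it is expected in this assay and the direction is held loosely. Compound 1, with its 3-methylphenyl group, gives 65.8 nM and this points weakly toward a lower number. The estimated step is a 1.3-fold lower number from compound 2 to compound 3 (0.12 log units; within the scatter) at most a small one. For compound 3 the expected value is 130 nM with an estimated range from 55 nM to 300 nM overall.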

Compound 3, half-maximal inhibitory concentration: 385 nM
The estimate for compound 3 lay 3.0-fold (0.47 log units) below the measured number; measured number outside the range, above it.
By their numbers in this assay, from the lowest: compound 1; then compound 2; then compound 3.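

Measured in this assay the swap of 4-chlorophenyl for 3-chloro-4-fluorophenyl on the sulfonamide nitrogen gives a 2.3-fold higher number from compound 2 to compound 3 (0.36 log units; beyond the scatter) and shows that this position still responds when the ring keeps its chlorine and gains a fluorine. The wider comparison gives a 5.9-fold higher number from compound 1 to compound 3 (0.77 log units; beyond the scatter) and places 3-methylphenyl lowest and 3-chloro-4-fluorophenyl highest of the three groups. No evidence is available to explain these differences.

The compounds shown leave open how an unsubstituted phenyl, 3-chlorophenyl or 4-fluorophenyl group would compare. The separate contributions of the chlorine and the fluorine therefore remain unresolved.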